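Chloro in place of methoxy on the benzoyl of compound 2

A few compounds are considered here, and "the series" means these few. Any claim that something is new, unique, unknown or untested is made for them only; others in the source may bear on it.

Of the compounds shown here, three have been measured in a functional assay on GLC82 cells (Homo sapiens) for cytotoxicity, read by MTT assay, with a stated time of 72 h; a higher number here means a weaker inhibitor, a lower number a stronger inhibitor. Compound 1 `COc1cc2ncnc(NNC(=S)NC(=O)c3cccc(Cl)c3)c2cc1OC` gives 8370 nM, compound 3 `COc1cc2ncnc(NNC(=S)NC(=O)c3ccccc3Cl)c2cc1OC` gives 10000 nM, and compound 2 `COc1ccccc1C(=O)NC(=S)NNc1ncnc2ccccc12` gives 9500 nM; all three numbers lie within the scatter of one another, so compound 2 stands level with the other two. Among the measured compounds shown here, the one measured step, a 1.2-fold higher number from compound 1 to compound 3 (0.08 log units; within the scatter), stayed within the scatter. Compound 4 `O=C(NC(=S)NNc1ncnc2ccccc12)c1ccccc1Cl` differs from compound 2 by chloro in place of methoxy on an aromatic carbon. For the measured compounds named here, no measured step swaps methoxy for chloro, and the chlorophenyl compounds 1 and 3 give numbers close to compound 2, so no step beyond the scatter is expected in this assay. Compound 4 is therefore estimated at 9500 nM, with a range from 4000 nM to 22000 nM. That means an expected step of no change at the digits printed from compound 2 to compound 4 (within the scatter).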

Compound 4, half-maximal inhibitory concentration: 10800 nM
Estimate against measurement, compound 4: 1.1-fold (0.06 log units) below; measured number inside the range.
By their numbers in this assay, from the lowest: compounds 1, 2, 3 and 4 (each within the scatter of the next).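

In this assay, exchanging methoxy for chloro on the aromatic carbon ortho to a large group gives a 1.1-fold higher number from compound 2 to compound 4 (0.06 log units; within the scatter). Among the compounds shown here, this is the first direct comparison of the two groups at this place, and it shows that the exchange leaves the reading level on this core, which the chlorine shift between the earlier compounds could not show. No evidence at hand accounts for this result.

From the compounds shown here alone, whether an amine or a carboxylic acid on this carbon would read level with methoxy and chloro remains open. So does the reading with plain hydrogen there.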